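This account rests on a few compounds, and the source may have more. Where it says the series, first, only, none or still open, it means among the compounds named here.

The measured compounds:

Compound 1, `O=c1[nH]cc(S(=O)(=O)Nc2cccc(-c3cn(-c4ccc(F)cc4)nn3)c2)c(=O)[nH]1`. In a functional assay on HepG2 cells (Homo sapiens) for antiproliferative activity, read by MTT assay, with a stated time of 24 h (a lower number here means a stronger inhibitor, a higher number a weaker inhibitor), compound 1 reaches only the limit > 20000 nM.
Compound 2, `O=c1[nH]cc(S(=O)(=O)Nc2cccc(-c3cn(-c4ccccc4Cl)nn3)c2)c(=O)[nH]1`. In this assay compound 2 gives 4030 nM.
Compound 3, `O=c1[nH]cc(S(=O)(=O)Nc2ccc(-c3cn(-c4ccc(F)cc4)nn3)cc2)c(=O)[nH]1`. In this assay compound 3 reaches only the limit > 20000 nM.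

Compound 4, `O=c1[nH]cc(S(=O)(=O)Nc2ccc(-c3cn(-c4ccccc4Cl)nn3)cc2)c(=O)[nH]1`, has not yet been measured in this assay. Compound 2 differs from compound 1 in one place, (2-chlorophenyl in place of 4-fluorophenyl on an aromatic nitrogen), and that change gave an at least 4.9-fold lower number from compound 1 to compound 2 (0.69 log units; beyond the scatter). The cores of compound 1 and compound 3 are built from the same atoms joined differently; the difference between the two cores is not broken down here. Compound 4 differs from compound 3 by the same change, (2-chlorophenyl in place of 4-fluorophenyl on an aromatic nitrogen), made at the same place. A step of similar size is therefore expected, an at least 3.3-fold lower number from compound 3 to compound 4 (0.52 log units; beyond the scatter), resting on an at least 4.9-fold lower number from compound 1 to compound 2 (0.69 log units; beyond the scatter) and on (the limit of > 20000 nM in this assay, at which 2 of the 3 values shown sit). Compound 4 is expected to give about 6000 nM, most likely between 2000 nM and 20000 nM.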

Compound 4, half-maximal inhibitory concentration: 2230 nM
Beside the measured number, compound 4's estimate is 2.7-fold (0.43 log units) above it; low and high end bracket the measured number.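

In this assay, putting 2-chlorophenyl in place of 4-fluorophenyl gives an at least 8.9-fold lower number from compound 3 to compound 4 (0.95 log units; beyond the scatter). Set beside the earlier step, this shows that the direction of the change carries over to the second core, but it does not show that the size of the step stays the same: the same change on two cores in this assay, an at least 4.9-fold lower number (0.69 log units; beyond the scatter) from compound 1 to compound 2 and an at least 8.9-fold lower number (0.95 log units; beyond the scatter) from compound 3 to compound 4; the limit leaves it open whether they differ. Both steps start from a limit of the assay, so each gives only a smallest possible size, not a true one: the limit of > 20000 nM in this assay, at which 2 of the 4 values shown sit.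

As far as these compounds go, the swap alters both the halogen and its place on the phenyl ring, so it remains open which of the two matters. A 2-fluorophenyl or a 4-chlorophenyl group on the same nitrogen could separate them.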